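The source may report more compounds than this note shows. Statements on the series, on what has been measured and on what is new or still open speak of the compounds shown alone.

For the measured compounds named here, compound 2 `COc1cc(-n2ncnc2-c2ccc(C)cc2)cc(OC)c1OC` is the only compound here with a numbered result: in a functional assay on Jurkat cells (Homo sapiens) for antiproliferative activity, read by MTT assay, with a stated time of 72 h (on this read-out lower numbers stand for stronger inhibition and higher numbers for weaker inhibition), compound 2 gives 300 nM. Compound 1 `COc1cc(-n2ncnc2-c2cccc([N+](=O)[O-])c2)cc(OC)c1OC` stands apart, since in this assay compound 1 gives > 10000 nM, which is a limit of the assay and not a number. Compound 3 `COc1cc(-n2ncnc2-c2cccc(F)c2)cc(OC)c1OC` has not yet been measured. It differs from compound 2 in one place: 3-fluorophenyl in place of 4-methylphenyl on an aromatic carbon. Going by the values given here, no measured pair shows a step of this kind, so its size is open. A step toward weaker inhibition, beyond the usual scatter, is expected as a 4.0-fold higher number from compound 2 to compound 3 (0.60 log units; beyond the scatter). Compound 3 is estimated at 1200 nM, between 300 nM and 6000 nM.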

Compound 3, half-maximal inhibitory concentration: > 10000 nM
Compound 3: only a limit was reported; the forecaster's own chance of this, stated with the estimate: 15%; at least 8.3-fold (0.92 log units) between middle value and limit.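

In this assay, 3-fluorophenyl in place of 4-methylphenyl gives an at least 33-fold higher number from compound 2 to compound 3 (1.52 log units; beyond the scatter), so this aromatic carbon does not accept every phenyl group of the same heavy-atom count. The value of compound 3, > 10000 nM, is a limit of the assay and not a number. The step between compound 1 and compound 3 cannot be read, and only compound 2 keeps a number: the limit of > 10000 nM in this assay, at which 2 of the 3 values shown sit.

From the compounds shown here alone, whether the loss follows the fluoro group itself or its place on the phenyl ring stays open. A 4-fluorophenyl or 3-methylphenyl group would separate these two, and how a 4-methoxyphenyl group fares here is also unknown.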